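Swapping the ring substituent on a kinase inhibitor series

The source may report more compounds than this note shows. Statements on the series, on what has been measured and on what is new or still open speak of the compounds shown alone.

Measured compounds:
compound 1 `CO[C@H]1CC[C@@H](Nc2cc(NCc3cnccc3C(F)(F)F)ncc2C#N)CC1` 58 nM
compound 2 `N#Cc1cnc(NCc2cnccc2C(F)(F)F)cc1N[C@H]1CC[C@@H](c2nc[nH]n2)CC1` 34 nM
compound 3 `N#Cc1cnc(NCc2cnccc2C(F)(F)F)cc1N[C@H]1CC[C@@H](n2cncn2)CC1` 100 nM

In an assay on isolated protein for inhibition of protein kinase C theta type (Homo sapiens), read by TR-FRET, with a stated time of 2 h (a higher number here means a weaker inhibitor, a lower number a stronger inhibitor), compound 1 gives 58 nM, which is the second highest number among the three measured compounds. Its neighbours sit close on either side: a 1.7-fold lower number from compound 1 to compound 2 (0.23 log units; within the scatter) and a 1.7-fold higher number from compound 1 to compound 3 (0.24 log units; within the scatter), so all three compounds are within the usual scatter of compound 1. Among the compounds with values here, the only step beyond the scatter is between the two triazole compounds, a 2.9-fold higher number from compound 2 to compound 3 (0.47 log units; beyond the scatter).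

Compound 4 `CC1(C)C[C@H](Nc2cc(NCc3cnccc3C(F)(F)F)ncc2C#N)CC[C@@H]1O` has not yet been measured. It differs from compound 1 in one place: 4-hydroxy-3,3-dimethylcyclohexyl in place of 4-methoxycyclohexyl on a nitrogen on an aromatic ring. Within the data shown here, no measured step makes the same change. The steps that come closest, from compound 1 to compound 2 and from compound 1 to compound 3, also alter the group on the saturated ring, and both stayed within the scatter. On that basis the expectation is for a number near that of compound 1, with no step beyond the scatter in either direction.

The estimate for compound 4 in this assay is 60 nM, within a range of 20 nM to 180 nM, which corresponds to an expected step of a 1.0-fold higher number from compound 1 to compound 4 (0.01 log units; within the scatter).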

Compound 4, half-maximal inhibitory concentration: 7 nM
For compound 4 the middle estimate is 8.6-fold (0.93 log units) above the measured one, outside the stated range (below it).
By their numbers in this assay, from the lowest: compound 4; then compounds 2, 1 and 3 (each within the scatter of the next, the first and the last beyond it).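

In this assay, within the data shown here, moving to the 4-hydroxy-3,3-dimethylcyclohexyl group gives an 8.3-fold lower number from compound 1 to compound 4 (0.92 log units; beyond the scatter), the only step from compound 1 that lies beyond the scatter, whereas a 1.7-fold lower number from compound 1 to compound 2 (0.23 log units; within the scatter) and a 1.7-fold higher number from compound 1 to compound 3 (0.24 log units; within the scatter) did not. This place on the shared core can therefore register a change in the group on the nitrogen, even though the two triazole swaps away from the 4-methoxycyclohexyl group showed nothing clear. The new group differs in more than one way, with a hydroxy in place of the methoxy and two added methyl groups on the ring, and no measurement here explains the lower number.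

The compounds shown do not separate those two parts of the change: a 4-hydroxycyclohexyl group, without the methyl groups, and a 4-methoxy-3,3-dimethylcyclohexyl group, with them, would show how much each part contributes. As far as these compounds go, it also remains open whether an amine in place of the hydroxy on the 3,3-dimethylcyclohexyl ring would give a number close to that of compound 4.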